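The source may report more compounds than this note shows. Statements on the series, on what has been measured and on what is new or still open speak of the compounds shown alone.

The compounds share one core and differ only in the aromatic group attached to it. Compound 1 `COc1cc(-c2ccnc3cc(-c4c[nH]c5ccccc45)nn23)cc(OC)c1OC` carries a 1H-indol-3-yl group, and in a functional assay on B16-F0 cells (Mus musculus) for inhibition, read by CCK-8 assay, with a stated time of 48 h (a lower number here means a stronger inhibitor, a higher number a weaker inhibitor), compound 1 gives 40 nM. Compound 2 `COc1cc(-c2ccnc3cc(-c4ccc(C)cc4)nn23)cc(OC)c1OC` carries a 4-methylphenyl group, and in this assay compound 2 gives 21 nM, the lowest of the three numbers; the step of a 1.9-fold lower number from compound 1 to compound 2 (0.28 log units; within the scatter) stays within the scatter. Compound 3 `COc1cc(-c2ccnc3cc(-c4ccc(C(C)=O)cc4)nn23)cc(OC)c1OC` carries a 4-acetylphenyl group, and in this assay compound 3 gives 3930 nM, a large loss seen in both a 190-fold higher number from compound 2 to compound 3 (2.27 log units; beyond the scatter) and a 98-fold higher number from compound 1 to compound 3 (1.99 log units; beyond the scatter). Compound 4 `COc1ccc(-c2cc3nccc(-c4cc(OC)c(OC)c(OC)c4)n3n2)cc1F` has not yet been measured. It differs from compound 2 by 3-fluoro-4-methoxyphenyl in place of 4-methylphenyl on an aromatic carbon. Within the data shown here, no measured step brings in a 3-fluoro-4-methoxyphenyl group, so the measured steps bear on it only loosely: exchanging one aromatic group for another cost little in one case and much in another. A modest shift toward a higher number is expected, possibly within the scatter. For compound 4 the estimate in this assay is 60 nM, with a range from 15 nM to 400 nM. That estimate means an expected step of a 2.9-fold higher number from compound 2 to compound 4 (0.46 log units; beyond the scatter).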

Compound 4, half-maximal inhibitory concentration: 3950 nM
Beside the measured number, compound 4's estimate is 66-fold (1.82 log units) below it, and the stated range ends below it.
By their numbers in this assay, from the lowest: compounds 2 and 1 (each within the scatter of the next); then compounds 3 and 4 (each within the scatter of the next).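

In this assay, putting 3-fluoro-4-methoxyphenyl in place of 4-methylphenyl is a large loss, a 190-fold higher number from compound 2 to compound 4 (2.27 log units; beyond the scatter), and the gap to the indole is also large, a 99-fold higher number from compound 1 to compound 4 (1.99 log units; beyond the scatter). This shows that the aromatic carbon on the five-membered ring tolerates far from every substituted phenyl group: a phenyl group with no carbonyl ends up level with the 4-acetylphenyl group, a 1.0-fold higher number from compound 3 to compound 4 (0.00 log units; within the scatter). The large loss seen earlier is therefore not peculiar to the acetyl group.

Nothing in the data explains what lies behind this loss. On these data alone, it remains open whether the fluorine, the methoxy group or the two together carry it, and how a plain 4-methoxyphenyl, a 3-fluorophenyl or a phenyl bearing an amine or a carboxylic acid would behave here.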